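Compound 4: an untested swap on the carbonyl side

The compounds below may be only part of what the source reports. "The series", "measured", "known", "first", "only" and "open" are said of these compounds alone.

Measured so far in a functional assay on HeLa cells (Homo sapiens) for antiproliferative activity, read by sulforhodamine B assay, with a stated time of 48 h; a higher number here means a weaker inhibitor, a lower number a stronger inhibitor
Compound 1 `COc1cc(OC)c2sc(-c3ccc(N/C=C\C(=O)c4ccc(OC)c(O)c4)c(C)c3)nc2c1` gives 16100 nM
Compound 2 `COc1cc(OC)c2sc(-c3ccc(N/C=C\C(=O)c4ccc(OC)c(O)c4)cc3)nc2c1` gives 12100 nM
Compound 3 `COc1ccc(C(=O)/C=C\Nc2ccc(-c3nc4cc(OC)c(OC)c(OC)c4s3)cc2)cc1O` gives 14100 nM

The two measured steps are a 1.3-fold lower number from compound 1 to compound 2 (0.12 log units; within the scatter) and a 1.2-fold higher number from compound 2 to compound 3 (0.07 log units; within the scatter) so compound 2 stands level with both of the other compounds in this assay and no real difference separates it from either.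

Compound 4 (`COc1cc(OC)c2sc(-c3ccc(N/C=C\C(=O)c4cc(OC)c(OC)c(OC)c4)cc3)nc2c1`) keeps the core of compound 2 but carries 3,4,5-trimethoxyphenyl in place of 3-hydroxy-4-methoxyphenyl on a carbonyl carbon. Among the compounds with values here, neither measured step alters this group, so they bear on the change only indirectly, and no measured compound tests it directly. With nothing pointing either way, no shift beyond the scatter is expected in either direction, though the uncertainty stays wide. The expected size is a 1.1-fold higher number from compound 2 to compound 4 (0.03 log units; within the scatter) on this reasoning. Compound 4 is estimated at 13000 nM with an expected range (5000 nM to 35000 nM).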

Compound 4, half-maximal inhibitory concentration: 17800 nM
Estimate against measurement, compound 4: 1.4-fold (0.14 log units) below; low and high end bracket the measured number.
By their numbers in this assay, from the lowest: compounds 2, 3, 1 and 4 (each within the scatter of the next).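

In this assay, within the data shown here, the group on the carbonyl carbon is changed for the first time, and 3,4,5-trimethoxyphenyl in place of 3-hydroxy-4-methoxyphenyl gives a 1.5-fold higher number from compound 2 to compound 4 (0.17 log units; within the scatter) and so stays within the scatter. The hydroxy group of compound 2 can therefore be lost, and the larger 3,4,5-trimethoxyphenyl group taken on, without a real difference in this read-out. No measurement in hand accounts for this result.

The compounds shown leave open whether any group on this carbonyl carbon can move the number beyond the scatter, for instance a phenyl ring carrying an amine or a carboxylic acid. They also leave open whether the same swap would behave alike on the core of compound 1 or compound 3.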